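The source may report more compounds than this note shows. Statements on the series, on what has been measured and on what is new or still open speak of the compounds shown alone.

Measured compounds:

Compound 1, `C[C@@H]1CN(c2ccc(C(F)(F)F)cn2)[C@@H](C)CN1S(=O)(=O)C[C@]12CC[C@H](CC1=O)C2(C)C`: 6310 nM
Compound 2, `CC1(C)[C@@H]2CC[C@@]1(CS(=O)(=O)N1CCN(c3ccc(C(F)(F)F)cn3)CC1)C(F)C2`: 794 nM

Both compounds were tested in a functional assay on CHO-K1 cells for antagonist activity at C-X-C chemokine receptor type 3 (Homo sapiens), read by FLIPR and calcium flux; a lower number here means a stronger inhibitor, a higher number a weaker inhibitor. Compound 2 holds the lower of the two numbers; compound 1 sits well above it, and the gap between the two lies beyond the usual scatter. Going by the values given here, the two compounds differ in more than one place, so the data show only what the two values show and give no single step to build on.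

Compound 3, `CCNC(=O)NC1C[C@H]2CC[C@]1(CS(=O)(=O)N1CCN(c3ccc(C(F)(F)F)cn3)CC1)C2(C)C`, has not yet been measured. It differs from compound 2 in one place: (ethylcarbamoyl)amino in place of fluoro on a saturated ring carbon. The shared core of compound 2 and compound 3 is otherwise kept, together with the piperazine sulfonamide and the trifluoromethyl-bearing pyridine.

Among the compounds with values here, no measured pair here shows what such a change at this position does, so the expected step carries wide uncertainty. Compound 3 is expected to stay near compound 2, with a step of a 1.3-fold higher number from compound 2 to compound 3 (0.10 log units; within the scatter), and no shift beyond the scatter is anticipated in either direction. The estimate for compound 3 in this assay is 1000 nM, with a range from 250 nM to 4000 nM.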

Compound 3, half-maximal inhibitory concentration: 794 nM
The estimate for compound 3 lay 1.3-fold (0.10 log units) above the measured number; the measured number falls inside the stated range.
By their numbers in this assay, from the lowest: compounds 2 and 3 (each within the scatter of the next); then compound 1.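

In this assay, going by these compounds alone, putting (ethylcarbamoyl)amino in place of fluoro on a saturated ring carbon gives no change at the digits printed from compound 2 to compound 3 (within the scatter), and this is the first step in the set that can be read at a single place. It shows that at this ring carbon, on a five-membered non-aromatic ring of carbon only and next to the ring atom that bears a large group, a single fluorine can give way to a group of 6 heavy atoms with 2 hydrogen-bond donors while the two values stay within the scatter of each other. No accompanying measurement offers an explanation for this result.

The compounds shown leave open how an amine, a carboxylic acid or a longer chain on the terminal nitrogen of the (ethylcarbamoyl)amino group would read at this ring carbon in this assay. They also leave open whether the same exchange would give a similar step on the core of compound 1, which differs from compound 2 in more than one place.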